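Pyridin-3-yl to pyridin-4-yl on a shared core

A few compounds are considered here, and "the series" means these few. Any claim that something is new, unique, unknown or untested is made for them only; others in the source may bear on it.

Measured in an ADME assay on HepG2 cells (Homo sapiens) for cytotoxicity, read by MTT assay, with a stated time of 72 h (a higher number here means that more compound is tolerated, a lower number that less compound is tolerated), so far:
Compound 1 `O=[N+]([O-])c1c(CS(=O)(=O)c2ccccc2)nc2c(-c3ccc(O)cc3)cc(Cl)cn12` gives > 12500 nM
Compound 2 `O=[N+]([O-])c1c(CS(=O)(=O)c2ccccc2)nc2c(-c3cccnc3)cc(Cl)cn12` gives > 31300 nM

Neither entry is a number, as each is a limit of the assay. Among the measured compounds shown here, compound 2 therefore stands at a limit, and the only other value shown, for compound 1, is a limit too. Compound 3 `O=[N+]([O-])c1c(CS(=O)(=O)c2ccccc2)nc2c(-c3ccncc3)cc(Cl)cn12` has not been measured. It differs from compound 2 as follows: pyridin-4-yl in place of pyridin-3-yl on an aromatic carbon with pyridin-4-yl in place of pyridin-3-yl on an aromatic carbon. For the measured compounds named here, the one measured step that bears on this is also a swap on an aromatic carbon, namely a step that the two limits leave unreadable from compound 1 to compound 2 and it offers no size to carry over. No step beyond the usual scatter is therefore expected in this assay in either direction. The expected change is an at least 1.0-fold lower number from compound 2 to compound 3 (0.01 log units; that floor lies within the scatter) and it should be read as an estimate only. For compound 3 the estimated value is 30000 nM with an expected range from 12000 nM to 70000 nM and a limit may well be expected again.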

Compound 3, half-maximal cytotoxic concentration: > 50000 nM
Compound 3 was reported as a limit (the forecaster's own chance of this, stated with the estimate: 75%); at least 1.6-fold (0.22 log units) between middle value and limit.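

Among the compounds shown here, compound 1, compound 2 and compound 3 are each reported only as a limit, not as a number, so no step between them can be read. Still open, from the compounds shown here alone, is how much of each compound is tolerated, and whether swapping these groups changes that at all.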